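Neopentyl replacing the hydroxylated group on the ring nitrogen

This account rests on a few compounds, and the source may have more. Where it says the series, first, only, none or still open, it means among the compounds named here.

The series shares one core carrying a substituted nitrogen, read in a functional assay on the whole organism for inhibition, with Nicotiana tabacum as the target; on this read-out higher numbers stand for weaker inhibition and lower numbers for stronger inhibition. Compound 1 `Cc1nc(NC2CCC2)c2cc[nH]c2n1` gives 74100000 nM. Compound 2 `C=CCNc1nc(C)nc2[nH]ccc12` gives 676000000 nM. Compound 3 `Cc1nc(NC(C)(C)O)c2cc[nH]c2n1` gives 166000000 nM, which places compound 3 second highest of the three measured numbers: the nearest is compound 1, with a 2.2-fold higher number from compound 1 to compound 3 (0.35 log units; beyond the scatter) separating them, and the furthest is compound 2, with a 4.1-fold lower number from compound 2 to compound 3 (0.61 log units; beyond the scatter) separating them.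

The next compound, compound 4 `Cc1nc(NCC(C)(C)C)c2cc[nH]c2n1`, differs from compound 3 in one place: neopentyl in place of 1-hydroxy-1-methylethyl on a nitrogen on an aromatic ring. For the measured compounds named here, of the measured steps, the one from compound 1 to compound 3 bears most directly, as it swaps a hydrocarbon group for the hydroxyl-bearing group at the same nitrogen and gives a 2.2-fold higher number from compound 1 to compound 3 (0.35 log units; beyond the scatter); the step to compound 4 runs the other way, back to a hydrocarbon group. The step from compound 2 to compound 3, a 4.1-fold lower number from compound 2 to compound 3 (0.61 log units; beyond the scatter), shows that not every hydrocarbon group at this nitrogen gives a lower number than the hydroxylated group. A modest lowering beyond the scatter is therefore expected in this assay, of about a 1.8-fold lower number from compound 3 to compound 4 (0.27 log units; within the scatter). Compound 4 is estimated at 90000000 nM, with a range from 30000000 nM to 270000000 nM.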

Compound 4, half-maximal inhibitory concentration: 200000000 nM
For compound 4 the middle estimate is 2.2-fold (0.35 log units) below the measured one, and the stated range covers the measured number.
By their numbers in this assay, from the lowest: compound 1; then compounds 3 and 4 (each within the scatter of the next); then compound 2.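

In this assay, exchanging 1-hydroxy-1-methylethyl for neopentyl on the nitrogen gives no readable change (a 1.2-fold higher number from compound 3 to compound 4 (0.08 log units; within the scatter)), so at this position the hydrogen-bond donor and acceptor counted for the group that leaves are not accompanied by a separable shift in the number for this pair. The hydrocarbon groups do not share a single level: neopentyl stands apart from cyclobutyl (a 2.7-fold higher number from compound 1 to compound 4 (0.43 log units; beyond the scatter)), and the step printed as tert-butyl in place of vinyl on the saturated chain carbon also lies beyond the scatter (a 3.4-fold lower number from compound 2 to compound 4 (0.53 log units; beyond the scatter)), so compounds 1, 2 and 4 all go against any reading in which a hydrocarbon group alone sets the number. No measurement is available to explain these differences.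

Cyclobutyl is the only ring among these nitrogen substituents, so one compound cannot separate the ring from its other features, and a cyclopentyl or cyclopropyl group on the same nitrogen would be needed to test it. Going by these compounds, the response of this position to a charged group, such as an amine or a carboxylic acid at the end of a longer chain, also remains open.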